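Phenoxy in place of 4-ethylphenyl on compound 2

The source may hold more compounds than are shown below. What is called first, only, known or untested is meant among the compounds shown, and "the series" means these compounds.

Compound 1 (`COC(=O)c1ccc(NC2=CC(=O)c3ncncc3C2=O)cc1`) gives 2200 nM in a functional assay on MIA PaCa-2 cells (Homo sapiens) for cytotoxicity, read by MTT assay, with a stated time of 72 h; on this read-out higher numbers stand for weaker inhibition and lower numbers for stronger inhibition
Compound 2 (`CCc1ccc(-c2ccc(NC3=CC(=O)c4ncncc4C3=O)cc2)cc1`) gives 2000 nM in this assay

Compound 2 stands level with compound 1, the two values lying within the scatter of each other. Compound 3 (`O=C1C(Nc2ccc(Oc3ccccc3)cc2)=CC(=O)c2ncncc21`) carries phenoxy in place of 4-ethylphenyl on an aromatic carbon. Among the compounds with values here, the one measured step that bears on this change is a 1.1-fold lower number from compound 1 to compound 2 (0.04 log units; within the scatter) with 4-ethylphenyl in place of methoxycarbonyl, and it stays within the scatter. No step beyond the scatter is therefore expected in this assay for compound 3. The estimate is no change at the digits printed from compound 2 to compound 3 (within the scatter) as the expected outcome. For compound 3 an estimated value of 2000 nM is expected, in a range from 800 nM to 5000 nM overall.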

Compound 3, half-maximal inhibitory concentration: 3700 nM
Compound 3: middle estimate off by 1.9-fold (0.27 log units), on the low side; the range from low to high includes it.
By their numbers in this assay, from the lowest: compounds 2, 1 and 3 (each within the scatter of the next).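

In this assay, phenoxy, which brings an oxygen that 4-ethylphenyl lacks, gives no step beyond the scatter (a 1.9-fold higher number from compound 2 to compound 3 (0.27 log units; within the scatter)). Against methoxycarbonyl the picture is the same (a 1.7-fold higher number from compound 1 to compound 3 (0.23 log units; within the scatter)), so all three groups at this aromatic carbon now lie within the scatter of one another. Nothing measured here offers an explanation for these values. Going by these compounds, whether an amine or a carboxylic acid on this aromatic carbon would give a step beyond the scatter remains open. The compounds shown also leave open how changes to the shared core would read out.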